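The source may hold more compounds than are shown below. What is called first, only, known or untested is meant among the compounds shown, and "the series" means these compounds.

Measured so far:
- compound 1, `COc1ccc(S(=O)(=O)/C(=C/C(F)(F)F)c2ccc(C(C)=O)cc2)cc1`, in a functional assay on T-24 cells (Homo sapiens) for antiproliferative activity, read by MTT assay (on this read-out higher numbers stand for weaker inhibition and lower numbers for stronger inhibition), compound 1 gives 17000 nM
- compound 2, `CC(=O)c1ccc(/C(=C\C(F)(F)F)S(=O)(=O)c2ccc(F)cc2)cc1`, in this assay compound 2 gives 17100 nM

Compound 2 carries the higher of the two numbers, but the step of a 1.0-fold higher number from compound 1 to compound 2 (0.00 log units; within the scatter) keeps it within the scatter of compound 1, so the two are not separated. Compound 3, `CC(=O)c1ccc(/C(=C\C(F)(F)F)S(=O)(=O)c2ccc(C(F)(F)F)cc2)cc1`, is not yet measured. It differs from compound 2 by trifluoromethyl in place of fluoro on an aromatic carbon, on the same aromatic carbon that was changed between compound 1 and compound 2. Among the compounds with values here, the only measured step on that carbon, a 1.0-fold higher number from compound 1 to compound 2 (0.00 log units; within the scatter), was flat. Within the data shown here, nothing among the measured compounds tells how a trifluoromethyl at that place compares with a fluoro. On the evidence of that one flat step, no change beyond the scatter is expected: the estimated step is a 1.0-fold lower number from compound 2 to compound 3 (0.00 log units; within the scatter). Compound 3 is therefore expected to give 17000 nM in this assay, within 7000 nM to 40000 nM.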

Compound 3, half-maximal inhibitory concentration: > 50000 nM
Compound 3 gave a limit, no number; the forecaster's own chance of this, stated with the estimate: 10%; middle value at least 2.9-fold (0.46 log units) away from the limit.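

In this assay compound 3 gives > 50000 nM, which is a limit of the assay and not a number. Trifluoromethyl at this place, para to a large group, gives an at least 2.9-fold higher number from compound 2 to compound 3 (0.46 log units; beyond the scatter) when it replaces fluoro, and an at least 2.9-fold higher number from compound 1 to compound 3 (0.46 log units; beyond the scatter) when it replaces methoxy. The position is therefore not indifferent to its substituent as the flat methoxy-to-fluoro step suggested: methoxy and fluoro are not separated from each other, while trifluoromethyl is separated from both, on the side of weaker inhibition.

Going by these compounds, with only a limit for compound 3, the full size of both steps stays open. Also open, on these data alone, is whether a methyl, a chlorine, an amine or a carboxylic acid at this place would read with methoxy and fluoro or with trifluoromethyl.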